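Series notes: five-membered ring variation, step to compound 4

This account rests on a few compounds, and the source may have more. Where it says the series, first, only, none or still open, it means among the compounds named here.

Measured compounds in an assay on isolated protein for inhibition of ubiquitin carboxyl-terminal hydrolase 7 (Homo sapiens), with stated times of 30 min and 2 h; on this read-out higher numbers stand for weaker inhibition and lower numbers for stronger inhibition:
compound 1, `Cn1nc2c(=O)n(CC3(O)CCN(Cc4ccc(-c5ncco5)cc4Cl)CC3)cnc2c1-c1ccc(CN)cc1`, 1120 nM
compound 2, `Cn1nc2c(=O)n(CC3(O)CCN(Cc4ccc(-c5cnco5)cc4Cl)CC3)cnc2c1-c1ccc(CN)cc1`, 71.6 nM
compound 3, `Cn1nc2c(=O)n(CC3(O)CCN(Cc4ccc(-c5ccc(C(=O)O)o5)cc4Cl)CC3)cnc2c1-c1ccc(CN)cc1`, 753 nM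

The shared core is held fixed; the three compounds differ only in the five-membered aromatic ring on the aromatic carbon meta to a chloro group. Compound 3 sits second highest of the three numbers: its nearest neighbour is compound 1 at a 1.5-fold lower number from compound 1 to compound 3 (0.17 log units; within the scatter), its furthest compound 2 at an 11-fold higher number from compound 2 to compound 3 (1.02 log units; beyond the scatter).

Compound 4, `Cn1nc2c(=O)n(CC3(O)CCN(Cc4ccc(-n5ccnc5)cc4Cl)CC3)cnc2c1-c1ccc(CN)cc1`, is not yet measured. It carries 1H-imidazol-1-yl in place of 5-carboxyfuran-2-yl on an aromatic carbon.

For the measured compounds named here, no measured step swaps in 1H-imidazol-1-yl, so the direct bearing is indirect. The same position has shown that the ring chosen matters a great deal: a 16-fold lower number from compound 1 to compound 2 (1.19 log units; beyond the scatter), while a 1.5-fold lower number from compound 1 to compound 3 (0.17 log units; within the scatter) stays small. So a change of this kind can move this assay by a large step or leave it flat, and the direction for an imidazole cannot be read from these three compounds alone. The expectation for compound 4 is therefore a modest improvement with wide uncertainty: a 2.2-fold lower number from compound 3 to compound 4 (0.33 log units; beyond the scatter) is the expected step, within a range spanning both flat and large outcomes.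

For compound 4 the estimate in this assay is 350 nM, expected to fall between 60 nM and 1500 nM.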

Compound 4, half-maximal inhibitory concentration: 228 nM
For compound 4 the middle estimate is 1.5-fold (0.19 log units) above the measured one, within the range that was stated.
By their numbers in this assay, from the lowest: compound 2; then compound 4; then compounds 3 and 1 (each within the scatter of the next).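

In this assay, for the compounds shown here, 1H-imidazol-1-yl gives a level not seen among the earlier compounds, with a 3.3-fold lower number from compound 3 to compound 4 (0.52 log units; beyond the scatter) and a 4.9-fold lower number from compound 1 to compound 4 (0.69 log units; beyond the scatter), while a 3.2-fold higher number from compound 2 to compound 4 (0.50 log units; beyond the scatter). The position therefore supports an intermediate result, not only the high numbers of compound 1 and compound 3 or the low number of compound 2. Removing the carboxyl group does not by itself set the level: compound 1, compound 2 and compound 4 all lack it yet remain apart, and compound 1 stays within the scatter of compound 3, which carries it; nothing available here accounts for this order.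

Still open, going by these compounds, is whether the advantage of 1,3-oxazol-5-yl over 1H-imidazol-1-yl persists when a methyl group or a carboxylic acid is placed on either ring, since the only carboxylic acid shown sits on a furan. A triazole or a thiazole at the same position would show whether compound 2 marks an isolated low number or part of a wider group of rings giving similar values.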